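This account rests on a few compounds, and the source may have more. Where it says the series, first, only, none or still open, it means among the compounds named here.

Of the compounds shown here, two have been measured in a functional assay on HeLa cells (Homo sapiens) for cytotoxicity, read by WST assay, with a stated time of 48 h; on this read-out higher numbers stand for weaker inhibition and lower numbers for stronger inhibition. Compound 1 `COc1ccc(/C=C/C[C@H]2C[C@H]([C@H](O)c3ccc(OC)c(OC)c3)CO[C@@H]2c2ccc(OC)c(OC)c2)cc1OC` gives 34600 nM. Compound 2 `Oc1ccc(/C=C/C[C@H]2C[C@@H]([C@@H](O)c3ccccc3)CO[C@@H]2c2ccccc2)cc1` gives 14400 nM, the lowest of the two numbers; its nearest neighbour is compound 1, which stands at a higher number, a gap beyond the usual scatter. Compound 3 `O[C@@H](c1ccccc1)[C@H]1CO[C@H](c2ccccc2)[C@@H](C/C=C/c2ccccc2F)C1` is the next compound to be measured in this assay. It differs from compound 2 in one place: 2-fluorophenyl in place of 4-hydroxyphenyl on a double-bonded chain carbon bound to a double-bonded chain carbon. Within the data shown here, no step between two measured compounds carrying a single change of this kind is available, so there is no measured precedent for a direction. The step from compound 2 to compound 3 is expected to be a 1.1-fold higher number from compound 2 to compound 3 (0.05 log units; within the scatter), which is taken as none beyond the scatter. Compound 3 is therefore expected to give 16000 nM, with a range from 6000 nM to 45000 nM.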

Compound 3, half-maximal inhibitory concentration: 9730 nM
Compound 3: the middle estimate sits 1.6-fold (0.22 log units) above what was measured; the measured number falls inside the stated range.
By their numbers in this assay, from the lowest: compounds 3 and 2 (each within the scatter of the next); then compound 1.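

In this assay, among these compounds, the first single-place step gives a 1.5-fold lower number from compound 2 to compound 3 (0.17 log units; within the scatter), with 2-fluorophenyl in place of 4-hydroxyphenyl on a double-bonded chain carbon bound to a double-bonded chain carbon. At this place, then, a group without hydrogen-bond donors or acceptors reads the same, within the scatter, as the 4-hydroxyphenyl group that has them, so the hydroxyl is not needed to hold the number at this level. Nothing at hand gives a reason for this result.

Going by these compounds, since the substituent and its ring position change together, the separate contributions of removing the hydroxyl and adding the fluorine stay open. Also open, on these data alone, is how an aminophenyl or carboxyphenyl group at this place, or a longer chain in place of the prop-2-en-1-yl link, would read.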